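Vinyl on the thiophene ring of compound 1

The compounds below may be only part of what the source reports. "The series", "measured", "known", "first", "only" and "open" are said of these compounds alone.

Measured so far:
Compound 1, `C[C@H]1[C@H](NCc2cccs2)C[C@H]2C[C@@H]1C2(C)C`, in an ADME assay on MDCK cells (Canis lupus familiaris) for cytotoxicity, read by microscopy, with a stated time of 48 h (a higher number here means that more compound is tolerated, a lower number that less compound is tolerated), gives 25000 nM.
Compound 2, `C[C@H]1[C@H](NCc2ccoc2)C[C@H]2C[C@@H]1C2(C)C`, gives > 100000 nM; this is a limit of the assay, not a number (the limit of > 100000 nM in this assay, at which 1 of the 3 values shown sits).
Compound 3, `CCCc1ccsc1CN[C@@H]1C[C@H]2C[C@@H]([C@H]1C)C2(C)C`, gives 50000 nM.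

Among the two actual numbers, compound 1 sits lowest; its nearest neighbour is compound 3, reached by a 2.0-fold higher number from compound 1 to compound 3 (0.30 log units; within the scatter), a step within the scatter. The third value is a limit only.

Compound 4 is `C=Cc1csc(CN[C@@H]2C[C@H]3C[C@@H]([C@H]2C)C3(C)C)c1`. Its difference from compound 1: vinyl in place of hydrogen on an aromatic carbon. The step that bears most directly on this change is a 2.0-fold higher number from compound 1 to compound 3 (0.30 log units; within the scatter), where propyl in place of hydrogen on an aromatic carbon did not move the number beyond the scatter. The other step, an at least 4.0-fold higher number from compound 1 to compound 2 (0.60 log units; beyond the scatter), exchanges one ring for another and so speaks less to a substituent change; it also ends at a limit. Vinyl entering an aromatic carbon is therefore expected to leave this assay within the scatter of compound 1. For compound 4 the expected step is a 1.2-fold higher number from compound 1 to compound 4 (0.08 log units; within the scatter). The estimate for compound 4 is 30000 nM, within 12500 nM to 100000 nM.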

Compound 4, minimum cytotoxic concentration: 6250 nM
Compound 4: the middle estimate sits 4.8-fold (0.68 log units) above what was measured; the whole stated range lies above it.
By their numbers in this assay, from the lowest: compound 4; then compounds 1 and 3 (each within the scatter of the next). At a limit, above all of these: compound 2.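

In this assay the step of a 4.0-fold lower number from compound 1 to compound 4 (0.60 log units; beyond the scatter) shows that a small carbon substituent on this thiophene ring can lower the tolerated concentration, with vinyl on an aromatic carbon two ring bonds from the ring sulfur. The earlier substituent step, a 2.0-fold higher number from compound 1 to compound 3 (0.30 log units; within the scatter) with propyl on an aromatic carbon, stayed within the scatter, so substitution on this ring does not leave the number unchanged in every case. No measurement shown here gives a cause for the lower number of compound 4.

As far as these compounds go, whether the step follows the double bond of vinyl or the place on the ring stays open. Ethyl at the same aromatic carbon would separate these two readings, and a longer chain there would show whether the number depends on substituent size.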